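The compounds below may be only part of what the source reports. "The series", "measured", "known", "first", "only" and "open" are said of these compounds alone.

Compound 1 `Cn1c(-c2cccc(Br)c2)cnc1NC(=O)c1ccc(F)cc1` — in a toxicity assay on THP-1 cells (Homo sapiens) for inhibition (on this read-out higher numbers stand for lower toxicity in this test and lower numbers for higher toxicity in this test), a limit of > 50000 nM.
Compound 2 `COc1ccc(-c2cnc(NC(=O)c3ccccc3OC)n2C)cc1` — in this assay a limit of > 100000 nM.
Compound 3 `COc1ccc(-c2cn(C)c(NC(=O)c3ccc(F)cc3)n2)cc1` — in this assay a limit of > 50000 nM.

None of the three measured values is a number; each is a limit. Compound 2 stands at the limit of > 100000 nM in this assay, at which 1 of the 3 values shown sits. The other two compounds stand at the limit of > 50000 nM in this assay, at which 2 of the 3 values shown sit. Nothing is known of any step between measured compounds that differ in a single place.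

Compound 4 `COc1ccc(-c2cnc(NC(=O)c3cnco3)n2C)cc1` differs from compound 2 by 1,3-oxazol-5-yl in place of 2-methoxyphenyl on a carbonyl carbon. With all three values sitting at limits, no step beyond the usual scatter in this assay is expected in either direction. Compound 4 is therefore expected to give 100000 nM, within 50000 nM to 200000 nM, most likely again as a limit. The expected step is a number no higher from compound 2 to compound 4 (the limit leaves the size open).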

Compound 4, half-maximal cytotoxic concentration: > 100000 nM
Compound 4 was reported as a limit; the forecaster's own chance of this, stated with the estimate: 80%; the middle value lies on the limit itself.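

Compound 2 and compound 4 are both reported only as limits in this assay, so no step can be read between them. The compounds shown leave open whether any change in structure shifts this read-out at all.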